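A Methyl Added on the Chain Beyond the Sulfur

The compounds below may be only part of what the source reports. "The series", "measured", "known", "first", "only" and "open" are said of these compounds alone.

In a physicochemical assay for lipophilicity (a higher number here means a more lipophilic compound, a lower number a more polar compound), compound 1 `COC(=O)/C=C(C)/C=C/CC(C)CCCC(C)(C)OC` gives 5. Compound 2 `CCOC(=O)/C=C(C)/C=C/CC(C)CCCC(C)(C)OC` differs from compound 1 by methyl in place of hydrogen on a saturated chain carbon bound to an oxygen next to a carbonyl group, and in this assay compound 2 gives 5.54; the step is a number 0.54 log units higher from compound 1 to compound 2 (beyond the scatter).

Compound 3 `CCSC(=O)/C=C(C)/C=C/CC(C)CCCC(C)(C)OC` has a different core: it differs from compound 1 by ethylsulfanyl in place of methoxy on a carbonyl carbon. In this assay compound 3 gives 6.78, which makes a number 1.78 log units higher from compound 1 to compound 3 (beyond the scatter) and, against compound 2, a number 1.24 log units higher from compound 2 to compound 3 (beyond the scatter). Compound 3 thus stands highest of the three measured compounds.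

Compound 4 `COC(C)(C)CCCC(C)C/C=C/C(C)=C/C(=O)SC(C)C` has not yet been measured. It differs from compound 3 by methyl in place of hydrogen on a saturated chain carbon bound to a saturated chain carbon and a sulfur. This is the same kind of change as from compound 1 to compound 2, but not the same change: there the place was on a saturated chain carbon bound to an oxygen next to a carbonyl group, here it is on a saturated chain carbon bound to a saturated chain carbon and a sulfur. Because the earlier step was a number 0.54 log units higher from compound 1 to compound 2 (beyond the scatter), a step of similar size is expected here, namely a number 0.52 log units higher from compound 3 to compound 4 (beyond the scatter). Compound 4 is therefore estimated at 7.3, with a likely range from 6.9 to 7.7.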

Compound 4, partition coefficient: 7.19
Compound 4: middle estimate off by 0.11 log units, on the high side; the measured number falls inside the stated range.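

In this assay, the methyl on the saturated chain carbon bound to a saturated chain carbon and a sulfur gives a number 0.41 log units higher from compound 3 to compound 4 (beyond the scatter), the same direction as the methyl step on the oxygen-bearing ester chain, a number 0.54 log units higher from compound 1 to compound 2 (beyond the scatter). The isopropylsulfanyl group in place of the oxygen groups on the carbonyl carbon gives larger steps, a number 1.65 log units higher from compound 2 to compound 4 (beyond the scatter) and a number 2.19 log units higher from compound 1 to compound 4 (beyond the scatter). So a single added methyl raised the number on both cores here, but these two steps are one pair at two different places, which does not show that the change would carry over to any other core, and nothing available bears on the reason for either step.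

The compounds shown leave open what isopropoxy on the carbonyl carbon would give, which would set the ethyl to isopropyl change directly on a core with oxygen at that point. Also open, going by these compounds, is what a longer chain such as butylsulfanyl, or an amine, would give at that same carbonyl carbon.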